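The source may hold more compounds than are shown below. What is called first, only, known or untested is meant among the compounds shown, and "the series" means these compounds.

Three compounds sharing the same core have been run in an ADME assay on isolated protein for inhibition of histone deacetylase 5 (Homo sapiens), read by fluorescence, with stated times of 30 min and 60 min; on this read-out higher numbers stand for weaker inhibition and lower numbers for stronger inhibition. Compound 1 `Cc1cccc(NC(=O)C(F)(F)C(F)(F)C(F)(F)C(F)(F)C(F)(F)C(F)(F)C(=O)NO)c1` returns only a limit of the assay, > 50000 nM. Compound 2 `O=C(NO)C(F)(F)C(F)(F)C(F)(F)C(F)(F)C(F)(F)C(F)(F)C(=O)Nc1ccc(I)cc1` likewise sits at a limit, > 50000 nM. Compound 3 `O=C(NO)C(F)(F)C(F)(F)C(F)(F)C(F)(F)C(F)(F)C(F)(F)C(=O)Nc1cccc(-c2ccccc2)c1` also gives a limit, > 50000 nM. The three measured steps, a step that the two limits leave unreadable from compound 1 to compound 2, a step that the two limits leave unreadable from compound 1 to compound 3 and a step that the two limits leave unreadable from compound 2 to compound 3, therefore cannot be read, as the limit of > 50000 nM in this assay, at which 3 of the 3 values shown sit, shows. Compound 3 thus stands with the other two at the limit and no order among the three can be stated.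

Compound 4 `O=C(NO)C(F)(F)C(F)(F)C(F)(F)C(F)(F)C(F)(F)C(F)(F)C(=O)Nc1cccc(-c2cn(-c3ccccc3)nn2)c1` differs from compound 3 by 1-phenyl-1H-1,2,3-triazol-4-yl in place of phenyl on an aromatic carbon. Going by the values given here, no measured step bears on this change in a readable way; all that is known is that three variations on the anilide have left every value at the limit. The expected step is accordingly a number no higher from compound 3 to compound 4 (the limit leaves the size open), that is, nothing that the assay would resolve. Compound 4 is expected to give 50000 nM, within 20000 nM to 150000 nM, and most probably to be reported once more only as a limit.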

Compound 4, inhibition constant: > 50000 nM
Compound 4 ended at the assay's limit (the forecaster's own chance of this, stated with the estimate: 85%); the middle value sits exactly at the limit.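

Neither the step from compound 3 to compound 4 nor the step from compound 1 to compound 4 can be read, because each joins two limits: the limit of > 50000 nM in this assay, at which 4 of the 4 values shown sit.
The compounds shown leave open how the four rank in this assay and whether any anilide on the shared core gives a measurable value there.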